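Quinoline sulfone series: aryl swap on the sulfonyl

This account rests on a few compounds, and the source may have more. Where it says the series, first, only, none or still open, it means among the compounds named here.

Measured compounds:
compound 1 `Cc1ccc2ncc(S(=O)(=O)c3ccc(F)cc3)c(N3CCC(C)CC3)c2c1` — 90%
compound 2 `CC1CCN(c2c(S(=O)(=O)c3ccc(F)c(Cl)c3)cnc3cc(Cl)ccc23)CC1` — 94%
compound 3 `CC1CCN(c2c(S(=O)(=O)c3ccc(F)c(Cl)c3)cnc3cc(F)ccc23)CC1` — 94%

All three were run in an assay on isolated protein for displacement of a labelled ligand from metabotropic glutamate receptor 5 (Homo sapiens), with a stated time of 60 min, tested at 1 uM; on this read-out lower numbers stand for less inhibition and higher numbers for more inhibition at the one concentration tested (going by the name of the read-out). Compound 2 stands level with compound 3, and these two sit highest of the three numbers; compound 1 lies a few points lower, but all three values fall within the scatter of one another, so no order among them is claimed.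

For the measured compounds named here, the only one-place step among the measured compounds is fluoro in place of chloro on an aromatic carbon, no change at the digits printed from compound 2 to compound 3 (within the scatter). It changes a substituent on the shared core rather than on the aryl group carried by the sulfonyl sulfur, so it bears only loosely on the next step.

Compound 4 `Cc1ccc(S(=O)(=O)c2cnc3cc(Cl)ccc3c2N2CCC(C)CC2)cc1C` differs from compound 2 as follows: 3,4-dimethylphenyl in place of 3-chloro-4-fluorophenyl on a sulfonyl sulfur. Two halogens leave and two methyls enter, so this is a different kind of change from the measured step. Comparing compound 1 and compound 2 shows that, with a different halogen pattern on the aryl carried by the sulfonyl sulfur, the two read-out numbers lie level within the scatter. Going by the values given here, no measured step informs a halogen-to-methyl swap directly. The expectation for compound 4 is therefore a value in this assay still high, with a step of a number 8 percentage points lower from compound 2 to compound 4 (within the scatter) likely within the scatter, but with a wider downside range than the measured data support with confidence. Compound 4 is estimated at 86%, range 65% to 97%.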

Compound 4, a percentage reported as inhibition, at one concentration (the size of the read-out at that concentration, not a potency): 86%
Compound 4: the middle estimate sits on the measured number at the digits printed; measured number inside the range.
By their numbers in this assay, from the lowest: compounds 4, 1, 2 and 3 (each within the scatter of the next).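

In this assay, 3,4-dimethylphenyl in place of 3-chloro-4-fluorophenyl on a sulfonyl sulfur gives a number 8 percentage points lower from compound 2 to compound 4 (within the scatter). This is the first one-place change among the compounds shown at the aryl group carried by the sulfonyl sulfur, and it shows that, for this pair on the shared core, the read-out stays within the scatter with both halogens replaced by methyl groups, so halogen on this aryl group is not needed to keep the number high in this pair. No measurement among those shown accounts for this outcome, so the result stands as an observation only.

As far as these compounds go, this single pair compares two aryl groups of the same size, each a six-membered aromatic ring of carbon only, so it remains open how the read-out responds to an aryl group carrying a carboxylic acid or an amine, or to a pyridine ring or a cyclohexyl group on the sulfonyl sulfur. The read-out is also taken at one concentration and is not a potency, so any real difference in potency between compound 2 and compound 4 remains unresolved.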